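The compounds below may be only part of what the source reports. "The series", "measured", "known", "first", "only" and "open" are said of these compounds alone.

Measured so far:
compound 1 `CCCN(CCC)c1ccc(C(=O)N2CCc3ccc(OS(N)(=O)=O)cc3C2)cc1` — 84.7%
compound 2 `CC(C)CCN(CCC(C)C)c1cccc(C(=O)N2CCc3ccc(OS(N)(=O)=O)cc3C2)c1` — 75.9%

Both were tested in an assay on HEK293 cells for inhibition of Steryl-sulfatase (Homo sapiens), tested at 1 uM; a higher number here means a stronger effect of the compound at the concentration tested, a lower number a weaker effect. Compound 2 stands alongside compound 1: the gap between their values lies within the usual scatter, so the two are not separable on these numbers. Among the compounds with values here, no step between measured pairs has been worked out.

Compound 3 `CN(CCCN1CCCCC1)c1cccc(C(=O)N2CCc3ccc(OS(N)(=O)=O)cc3C2)c1` is the next compound. It differs from compound 2 by methyl(3-(piperidin-1-yl)propyl)amino in place of diisopentylamino on an aromatic carbon. Within the data shown here, with no comparable step available, the expected change is a modest drop from compound 2 to compound 3, a number 12.9 percentage points lower from compound 2 to compound 3 (beyond the scatter), at or slightly beyond the scatter. Compound 3 is estimated at 63%, with a range of 35% to 85%.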

Compound 3, a percentage reported as inhibition, at one concentration (the size of the read-out at that concentration, not a potency): 30.6%
For compound 3 the middle estimate is 32.4 percentage points above the measured one; measured number outside the range, below it.
By their numbers in this assay, from the lowest: compound 3; then compounds 2 and 1 (each within the scatter of the next).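

In this assay the amine on this aromatic carbon matters: methyl(3-(piperidin-1-yl)propyl)amino in place of diisopentylamino gives a number 45.3 percentage points lower from compound 2 to compound 3 (beyond the scatter) and the step is large. The heavy-atom count stays the same across this change, while the entering group brings a second nitrogen and a six-membered non-aromatic ring. Nothing at hand bears on why the step occurs.

Still open, going by these compounds, is which part of the entering group goes with the step: the piperidine ring, the second nitrogen or the methyl on the amine. A morpholine ring or a terminal dimethylamino group on the same propyl chain would help separate these.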